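The compounds below may be only part of what the source reports. "The series", "measured", "known", "first", "only" and "open" are said of these compounds alone.

Measured compounds:
compound 1 `Nc1ccccc1NC(=O)c1ccc(CSC(=S)N2CCN(Cc3ccccn3)CC2)cc1` — 65.2% in a functional assay on MGC-803 cells (Homo sapiens) for antiproliferative activity, read by CCK-8 assay, with a stated time of 72 h, tested at 8 uM; a higher number here means a stronger effect of the compound at the concentration tested, a lower number a weaker effect
compound 2 `Nc1ccccc1NC(=O)c1ccc(CSC(=S)N2CCN(C3CCCCC3)CC2)cc1` — 75.3% in this assay
compound 3 `Nc1ccccc1NC(=O)c1ccc(CSC(=S)N2CCc3cc([N+](=O)[O-])ccc32)cc1` — 33.2% in this assay

Compound 3 stands lowest of the three numbers in this assay; compound 1 lies nearer to it and compound 2 furthest, both beyond the scatter. Among the measured compounds shown here, the single measured step, a number 10.1 percentage points higher from compound 1 to compound 2 (beyond the scatter), concerns the substituent on an amine nitrogen in a ring of the shared core and gives a modest rise.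

Compound 4 `Nc1ccccc1NC(=O)c1ccc(CSC(=S)N2CCc3ccccc32)cc1` is not yet measured. It differs from compound 3 in one place: hydrogen in place of nitro on an aromatic carbon. For the measured compounds named here, no measured step touches this position or this group; the step from compound 1 to compound 2 changes a different part of the molecule and does not bear on the removal of the nitro. Going by the values given here, the numbers for compounds 1 and 2 show only that cores without a nitro can reach higher inhibition, but those cores also lack the fused ring of compound 3, so nothing firm follows for the direction. The expected step in this assay is therefore uncertain, with a lean toward a small rise, as a number 11.8 percentage points higher from compound 3 to compound 4 (beyond the scatter). Compound 4 is estimated at 45%, within 25% to 70%.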

Compound 4, a percentage reported as inhibition, at one concentration (the size of the read-out at that concentration, not a potency): 87%
Estimate against measurement, compound 4: 42 percentage points below; measured number outside the range, above it.
By their numbers in this assay, from the lowest: compound 3; then compound 1; then compound 2; then compound 4.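

In this assay, hydrogen in place of nitro on an aromatic carbon of a six-membered aromatic ring of carbon only, part of a fused or bridged system of two rings, gives a number 53.8 percentage points higher from compound 3 to compound 4 (beyond the scatter) and marks this carbon as a place where the read-out responds strongly to the substituent. Among the compounds shown here, the only earlier step, a number 10.1 percentage points higher from compound 1 to compound 2 (beyond the scatter), lay on an amine nitrogen in a ring, was modest, and gave no reading at this carbon; between the two groups now seen here, hydrogen gives the higher inhibition at the tested concentration. Nothing at hand accounts for the size of this step.

With only nitro and hydrogen shown at this carbon, it remains open whether the lower number belongs to nitro in particular or to any group there, and a fluorine, a methoxy, an amine or a nitrile at the same carbon would separate these two readings. Going by these compounds, the read-out also stands at one concentration on one cell line, so potency and the behaviour of compound 4 in other cell lines remain open.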